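A few compounds are considered here, and "the series" means these few. Any claim that something is new, unique, unknown or untested is made for them only; others in the source may bear on it.

In an ADME assay on MDCK cells (Canis lupus familiaris) for permeability, in the apical to basolateral direction (a lower number here means that the compound crosses the layer more slowly, a higher number that the compound crosses the layer faster), compound 1 (`CC(C)C(CC1C(=O)NC(=O)N1C)c1ccc(-c2ccc3cccc(F)c3c2)[nH]c1=O`) gives 17.6 10^-6 cm/s. Compound 2 (`CC(C)C(c1ccc(-c2ccc3cccc(F)c3c2)[nH]c1=O)C1NC(=O)NC1=O`) has no number to stand on, and its result reads "not determined" (no result reported). Compound 3 (`CC(C)C(c1ccc(-c2ccc3cccc(F)c3c2)[nH]c1=O)C1SC(=O)NC1=O`) is still to be measured. The change leading to it is 2,4-dioxo-1,3-thiazolidin-5-yl in place of 2,5-dioxoimidazolidin-4-yl on a saturated chain carbon bound to an aromatic carbon and a saturated chain carbon, which puts 2,4-dioxo-1,3-thiazolidin-5-yl in place of 2,5-dioxoimidazolidin-4-yl on a saturated chain carbon. Within the data shown here, with no starting value, no step beyond the scatter is expected in this assay, in either direction, and the only anchor is compound 1 at 17.6 10^-6 cm/s. For compound 3 the expected value is 14 10^-6 cm/s, with an estimated range of 6 10^-6 cm/s to 28 10^-6 cm/s.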

Compound 3, apparent permeability: 26.3 10^-6 cm/s
Compound 3: the middle estimate sits 1.9-fold (0.27 log units) below what was measured; the range from low to high includes it.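

With compound 3, this position gains a second reading in this assay and shows that a sulfur-containing ring can stand on the saturated chain carbon. Replacing (3-methyl-2,5-dioxoimidazolidin-4-yl)methyl with 2,4-dioxo-1,3-thiazolidin-5-yl gives a 1.5-fold higher number from compound 1 to compound 3 (0.17 log units; within the scatter) and so leaves the two compounds indistinguishable here. The direct step from compound 2 cannot be read, and no supporting data explain the result.

On these data alone, it remains open how a carboxylic acid or an amine at this saturated chain carbon would read in this assay and whether either would stay within the scatter of compound 3.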